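Notes on the group on the ring nitrogen

The source may report more compounds than this note shows. Statements on the series, on what has been measured and on what is new or still open speak of the compounds shown alone.

Measured in an assay on V79 cells for inhibition of cytochrome P450 11B2, mitochondrial (Homo sapiens), read by HTRF, with a stated time of 1 h; a lower number here means a stronger inhibitor, a higher number a weaker inhibitor:
compound 1 `Fc1ccc2nc(-c3cccnc3)n(C3CC3)c2c1` gives 4 nM
compound 2 `CC(C)(C)n1c(-c2cccnc2)nc2ccc(F)cc21` gives > 5000 nM

Compound 2 stands at the edge of what this assay reports: its value > 5000 nM is a limit of the assay and not a number (the limit of > 5000 nM in this assay, at which 1 of the 2 values shown sits). Compound 3 `Fc1ccc2nc(-c3cccnc3)[nH]c2c1` differs from compound 2 by hydrogen in place of tert-butyl on an aromatic nitrogen. Within the data shown here, one measured step bears on this position: an at least 1200-fold higher number from compound 1 to compound 2 (3.09 log units; beyond the scatter), in which cyclopropyl gave way to tert-butyl. The move to compound 3 removes the tert-butyl altogether, leaving hydrogen where compound 1 carried the small ring. A large step back to a lower number in this assay is therefore expected, an at least 160-fold lower number from compound 2 to compound 3 (2.22 log units; beyond the scatter), though with compound 2 at a limit only the least size of that step is anchored. For compound 3 the estimate in this assay is 30 nM, within a range from 5 nM to 300 nM.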

Compound 3, half-maximal inhibitory concentration: > 10000 nM
Compound 3 ended at the assay's limit; the forecaster's own chance of this, stated with the estimate: 5%; middle value at least 330-fold (2.52 log units) from the limit.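

In this assay compound 3 gives > 10000 nM, which is a limit of the assay and not a number: the limit of > 10000 nM in this assay, at which 1 of the 3 values shown sits.

With hydrogen on the aromatic nitrogen, the low number of compound 1 is lost as well, with an at least 2500-fold higher number from compound 1 to compound 3 (3.39 log units; beyond the scatter), so of the three groups shown at this position only cyclopropyl gives a measurable inhibitor. Compound 2 also stands at a limit, so the step from it to compound 3 cannot be read: the limit of > 5000 nM in this assay, at which 1 of the 3 values shown sits.

With only hydrogen, cyclopropyl and tert-butyl shown on this nitrogen, it stays open whether methyl, ethyl, isopropyl or cyclobutyl would keep a number close to that of compound 1. As far as these compounds go, it also stays open whether a longer chain ending in an amine or a carboxylic acid would be accepted here.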